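This account rests on a few compounds, and the source may have more. Where it says the series, first, only, none or still open, it means among the compounds named here.

Three compounds carry numbers in an assay for inhibition of serine/threonine-protein kinase PLK2 (Homo sapiens), read by FRET and Z'-LYTE, with a stated time of 1 h; a lower number here means a stronger inhibitor, a higher number a weaker inhibitor. Compound 1 `CCC1C(=O)N(C)c2cnc(-n3ccc4cc(C(=O)NC(C)C)ccc43)nc2N1c1ccn(C)n1` gives 125 nM. Compound 2 `CCC1C(=O)N(C)c2cnc(Nc3ccc(S(=O)(=O)NCCO)cc3)nc2N1c1ccn(C)n1` gives 478 nM. Compound 3 `CC[C@@H]1C(=O)N(C)c2cnc(-n3ccc4ccccc43)nc2N1C1CCCC1` gives 355 nM, the second highest of the three numbers; against compound 2 the gap lies within the scatter, against compound 1 it lies beyond it, with compound 1 at the lower number. Compound 4 `CCNC(=O)c1ccc2c(ccn2-c2ncc3c(n2)N(C2CCCC2)[C@H](CC)C(=O)N3C)c1` differs from compound 3 in one place: ethylcarbamoyl in place of hydrogen on an aromatic carbon. Among the measured compounds shown here, no step between measured compounds isolates this change; compound 1 carries a related carbamoyl but differs from compound 3 in a second place as well. In this assay the expected step is a 2.7-fold lower number from compound 3 to compound 4 (0.44 log units; beyond the scatter), toward a lower number and beyond the scatter. Compound 4 is estimated at 130 nM, with a range from 50 nM to 400 nM.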

Compound 4, half-maximal inhibitory concentration: 4.88 nM
For compound 4 the middle estimate is 27-fold (1.43 log units) above the measured one, and the stated range ends above it.
By their numbers in this assay, from the lowest: compound 4; then compound 1; then compounds 3 and 2 (each within the scatter of the next).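

In this assay, ethylcarbamoyl in place of hydrogen on an aromatic carbon of the six-membered ring of carbon only gives a 73-fold lower number from compound 3 to compound 4 (1.86 log units; beyond the scatter) as a large step. Among the compounds shown here, this is the first step that isolates a single change, and it marks this position as highly sensitive to substitution. No measurement shown accounts for the size of the step.

On these data alone, whether a longer chain on the amide nitrogen keeps this gain remains open. So does the outcome with a carboxylic acid or an amine at the same carbon.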